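The source may report more compounds than this note shows. Statements on the series, on what has been measured and on what is new or still open speak of the compounds shown alone.

Measured compounds: compound 1 `COc1ccc(Cl)cc1-n1ncc(-c2nnc(-c3cccc(F)c3)o2)c1C` with 4.28; compound 2 `COc1ccc(Cl)cc1-n1ncc(-c2nnc(-c3ccc(Br)c(C)c3)o2)c1C` with 5.2; compound 3 `COc1ccc(Cl)cc1-n1ncc(-c2nnc(-c3ccc(C)c(Br)c3)o2)c1C` with 5.19, all in a physicochemical assay for lipophilicity, using the shake flask method, measured as octanol-water partition; a lower number here means a more polar compound, a higher number a more lipophilic compound.

Compound 2 stands at the top of these three numbers in this assay: its nearest neighbour is compound 3, which lies a number 0.01 log units lower from compound 2 to compound 3 (within the scatter), a gap within the scatter, and its furthest is compound 1, which lies a number 0.92 log units higher from compound 1 to compound 2 (beyond the scatter) below it, well beyond the scatter.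

Compound 4 `COc1ccc(Cl)cc1-n1ncc(-c2nnc(-c3ccc(Cl)cc3)o2)c1C` is not yet measured. It differs from compound 2 in one place: 4-chlorophenyl in place of 4-bromo-3-methylphenyl on an aromatic carbon.

Among the measured compounds shown here, two measured steps bear on this change. From compound 1 to compound 2 the partition coefficient rose a number 0.92 log units higher from compound 1 to compound 2 (beyond the scatter), and from compound 1 to compound 3 it rose a number 0.91 log units higher from compound 1 to compound 3 (beyond the scatter); both exchange a single halogen on the phenyl for a bromine together with a methyl. The step to compound 4 runs the other way in part, from bromine with methyl back to a single halogen, but to chlorine rather than fluorine. Compound 4 is therefore expected to sit between compound 1 and compound 2, with a step of a number 0.60 log units lower from compound 2 to compound 4 (beyond the scatter) expected from compound 2. The estimate for compound 4 is 4.6, with a range from 4.3 to 4.9.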

Compound 4, partition coefficient: 4.51
Beside the measured number, compound 4's estimate is 0.09 log units above it; measured number inside the range.
By their numbers in this assay, from the lowest: compounds 1 and 4 (each within the scatter of the next); then compounds 3 and 2 (each within the scatter of the next).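

In this assay, the new compound shows that the gap at this position, on the aromatic carbon of the five-membered ring, holds when the single halogen is chlorine and not only fluorine: a number 0.69 log units lower from compound 2 to compound 4 (beyond the scatter), and a number 0.68 log units lower from compound 3 to compound 4 (beyond the scatter), both beyond the scatter. The two single-halogen phenyl groups do not separate, as a number 0.23 log units higher from compound 1 to compound 4 (within the scatter) stays within the scatter, so among these four compounds the 4-bromo-3-methylphenyl and 3-bromo-4-methylphenyl groups stand apart from the 4-chlorophenyl and 3-fluorophenyl groups, with no compound going against that split. No measurement is available that would account for these differences.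

Each step beyond the scatter exchanges the halogen and removes the methyl in a single change, so these compounds cannot show how much of the gap goes with the bromine and how much with the methyl, and a phenyl carrying bromine alone or methyl alone would be needed to part the two. Where a phenyl bearing an amine or a carboxylic acid would fall in this assay also remains open, since every group shown here is a halogen or methyl on the phenyl.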